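Hydrazone aryl swap: dichloro to dimethoxy

This account rests on a few compounds, and the source may have more. Where it says the series, first, only, none or still open, it means among the compounds named here.

Two hydrazone ureas on a shared core have been measured in a functional assay on MKN-45 cells (Homo sapiens) for cytotoxicity, read by MTT assay, with a stated time of 72 h; a higher number here means a weaker inhibitor, a lower number a stronger inhibitor. Compound 1 `COc1ccc(/C=N/NC(=O)Nc2ccc(Oc3ccnc4cc(OCCCN5CCCCC5)c(OC)cc34)c(F)c2)cc1` carries a 4-methoxyphenyl on the carbon with a double bond to nitrogen, and in this assay compound 1 gives 660 nM. Compound 2 `COc1cc2c(Oc3ccc(NC(=O)N/N=C/c4ccc(Cl)cc4Cl)cc3F)ccnc2cc1OCCCN1CCCCC1` carries a 2,4-dichlorophenyl at that carbon, and in this assay compound 2 gives 460 nM. The step of a 1.4-fold lower number from compound 1 to compound 2 (0.16 log units; within the scatter) is within the scatter, so compound 2 and compound 1 are not separated by the numbers shown; compound 2 merely holds the smaller of two values that overlap.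

Compound 3 `COc1ccc(/C=N/NC(=O)Nc2ccc(Oc3ccnc4cc(OCCCN5CCCCC5)c(OC)cc34)c(F)c2)c(OC)c1` is the next member: 2,4-dimethoxyphenyl in place of 2,4-dichlorophenyl on a carbon with a double bond to nitrogen. Among the measured compounds shown here, only one step bears on this change, the one from compound 1 to compound 2, which exchanged a single methoxy-bearing ring for the dichloro ring with no movement beyond the scatter. Returning to a methoxy-bearing ring, now with two methoxy groups, is therefore expected to give a step of a 1.3-fold higher number from compound 2 to compound 3 (0.12 log units; within the scatter) of no size beyond the scatter. For compound 3 the expected value in this assay is 600 nM, with a range from 250 nM to 1500 nM.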

Compound 3, half-maximal inhibitory concentration: 1990 nM
Compound 3: middle estimate off by 3.3-fold (0.52 log units), on the low side; measured number outside the range, above it.
By their numbers in this assay, from the lowest: compounds 2 and 1 (each within the scatter of the next); then compound 3.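

In this assay the change to 2,4-dimethoxyphenyl gives a 4.3-fold higher number from compound 2 to compound 3 (0.64 log units; beyond the scatter) and so shows that the aryl group on the carbon with a double bond to nitrogen can move the number beyond the scatter, which the earlier exchange of 4-methoxyphenyl for 2,4-dichlorophenyl did not show. A single added methoxy is enough to produce a separation, since methoxy in place of hydrogen on an aromatic carbon gives a 3.0-fold higher number from compound 1 to compound 3 (0.48 log units; beyond the scatter) in a pair that differs in that one place. Compound 3 therefore stands apart from both compound 1 and compound 2, while those two remain within the scatter of each other, so the presence of a methoxy group does not by itself set the number in this small set. Nothing measured here accounts for the higher number of compound 3.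

From the compounds shown here alone, whether the step follows from the second methoxy specifically or would also appear with another group in its place, such as an ethoxy, a hydroxyl or a dimethylamino group, stays open. Three aryl groups on one shared core also leave open how a ring bearing a single chlorine or a nitrile would sit relative to compound 2 and compound 3.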